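The source may hold more compounds than are shown below. What is called first, only, known or untested is meant among the compounds shown, and "the series" means these compounds.

In a functional assay on DU-145 cells (Homo sapiens) for inhibition, read by trypan blue exclusion, with a stated time of 96 h (a higher number here means a weaker inhibitor of growth, a lower number a stronger inhibitor of growth), compound 1 `CN(C)c1ccc(/C=C(/SCc2ccc(Cl)cc2)C(=O)c2ccc(C(=O)O)cc2)cc1` gives 1000 nM. Compound 2 `O=C(O)c1ccc(C(=O)/C(=C\c2ccc(Cl)c([N+](=O)[O-])c2)SCc2ccc(Cl)cc2)cc1` gives 1000 nM, which leaves it level with compound 1 at the digits shown. Compound 3 `O=C(O)c1ccc(C(=O)/C(=C\c2ccc(Br)c([N+](=O)[O-])c2)SCc2ccc(Cl)cc2)cc1` is reported only as a limit, < 1000 nM.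

Compound 4 `CN(C)c1ccc(/C=C(/SCc2ccc(F)cc2)C(=O)c2ccc(C(=O)O)cc2)cc1` keeps the core of compound 1 and makes one small change: fluoro in place of chloro on an aromatic carbon. This puts fluoro in place of chloro on an aromatic carbon, para to a large group, so 4-chlorobenzyl becomes 4-fluorobenzyl.

Among the compounds with values here, no measured step touches this group. The nearest parallel is another halogen swap, bromo in place of chloro on an aromatic carbon, elsewhere in the molecule, where the step reads a number no higher from compound 2 to compound 3 (the limit leaves the size open). Its size cannot be read. A far larger replacement, 4-chloro-3-nitrophenyl in place of 4-(dimethylamino)phenyl, gives no change at the digits printed from compound 1 to compound 2 (within the scatter).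

On that evidence, no shift beyond the scatter is expected, and neither direction is favoured. The expected change is no change at the digits printed from compound 1 to compound 4 (within the scatter).

The estimate for compound 4 is 1000 nM, with an expected range of 400 nM to 2500 nM.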

Compound 4, concentration for 50% growth inhibition: 10000 nM
Beside the measured number, compound 4's estimate is 10-fold (1.00 log units) below it; measured number above the stated range.
By their numbers in this assay, from the lowest: compounds 1 and 2 (each within the scatter of the next); then compound 4.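

In this assay, replacing 4-chlorobenzyl with 4-fluorobenzyl exchanges one heavy atom for one, with no hydrogen-bond donor, acceptor or net charge entering or leaving, yet it gives a 10-fold higher number from compound 1 to compound 4 (1.00 log units; beyond the scatter). This position therefore responds to the identity of a single halogen, whereas the far larger replacement on the other side of the molecule gives no change at the digits printed from compound 1 to compound 2 (within the scatter). The steps to compound 3 cannot be read, since compound 3 is reported only as a limit: the limit of < 1000 nM in this assay, at which 1 of the 4 values shown sits.

The compounds shown leave open how a bromo group, a methyl group or a plain hydrogen at this place would compare with chloro and fluoro. They also leave open whether the same exchange would have a similar effect on the core of compound 2.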